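Tetrazole aryl exchange on the cyclohexyl pyrazole amide

This account rests on a few compounds, and the source may have more. Where it says the series, first, only, none or still open, it means among the compounds named here.

Among the measured compounds shown here, compound 3 `Cc1cc(NC(=O)Cn2nnc(-c3cccnc3)n2)n(C2CCCCC2)n1` gives 1930 nM in an assay on HEK293 cells for activation of Kir3.1/Kir3.2 (Homo sapiens), read by thallium flux (on this read-out lower numbers stand for an effect already at smaller amounts and higher numbers for an effect only at larger amounts of compound), the lowest of the two numbers measured so far. Compound 2 `Cc1cc(NC(=O)Cn2nnc(-c3ccccc3)n2)n(-c2ccccc2)n1` gives 3020 nM in this assay, a gap to compound 3 that stays within the scatter. Compound 1 `Cc1cc(NC(=O)Cn2nnc(-c3ccccc3)n2)n(C2CC2)n1` reaches only a limit of the assay, > 5000 nM, namely (the limit of > 5000 nM in this assay, at which 1 of the 3 values shown sits). For the measured compounds named here, the single measured step, an at least 1.6-fold lower number from compound 1 to compound 2 (0.21 log units; that floor lies within the scatter), concerns the group on the aromatic nitrogen of the shared core, with phenyl in place of cyclopropyl, and its floor lies within the scatter.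

Compound 4 `COc1ccc(-c2nnn(CC(=O)Nc3cc(C)nn3C3CCCCC3)n2)cc1` differs from compound 3 at a different site: 4-methoxyphenyl in place of pyridin-3-yl on an aromatic carbon. Going by the values given here, no measured step touches this aromatic carbon, and the exchange of pyridin-3-yl for 4-methoxyphenyl therefore has no precedent among the measured pairs. Accordingly no step beyond the scatter is expected in this assay in either direction. Compound 4 is expected to give about 1600 nM, with a range from 500 nM to 5000 nM. That estimate means an expected step of a 1.2-fold lower number from compound 3 to compound 4 (0.08 log units; within the scatter).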

Compound 4, half-maximal effective concentration: 175 nM
Estimate against measurement, compound 4: 9.1-fold (0.96 log units) above, outside the stated range (below it).
By their numbers in this assay, from the lowest: compound 4; then compounds 3 and 2 (each within the scatter of the next). At a limit, above all of these: compound 1.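

The aryl group on the aromatic carbon of the five-membered aromatic ring with 4 nitrogen proves to be a sensitive site in this assay: 4-methoxyphenyl in place of pyridin-3-yl gives an 11-fold lower number from compound 3 to compound 4 (1.04 log units; beyond the scatter). This is the first step in the series shown to lie beyond the scatter, whereas the only earlier step, at the group on the aromatic nitrogen, has a floor within it. No measured property at hand accounts for the size of this step.

Among the compounds shown here, the one pair removes the ring nitrogen and brings in the methoxy group at once, so it remains open which of the two changes goes with the step. Also open, on these data alone, is how an ethoxy group or an amine in place of the methoxy group would read in this assay, and whether the step holds with phenyl or cyclopropyl on the aromatic nitrogen.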